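Varying the Amide Aryl Group: From Compound 3 to Compound 4

This account rests on a few compounds, and the source may have more. Where it says the series, first, only, none or still open, it means among the compounds named here.

Of the compounds shown here, three built on one shared core have been measured in a functional assay on HEK293 cells for agonist activity at D(4) dopamine receptor (Homo sapiens), read by FLIPR; a higher number here means a larger maximal response, a lower number a smaller maximal response. Compound 1 `O=C(CN1CCC(c2cccc[n+]2[O-])CC1)NC1CCCCC1` carries a cyclohexyl group on the amide-type nitrogen and gives 58%. Compound 2 `O=C(CN1CCC(c2cccc[n+]2[O-])CC1)Nc1ccc(F)cc1` carries a 4-fluorophenyl group there and gives 71%, while compound 3 `O=C(CN1CCC(c2cccc[n+]2[O-])CC1)Nc1ccccc1F` carries a 2-fluorophenyl group and gives 63%. Among these three numbers compound 3 stands second highest; its nearest neighbour is compound 1, and its gap to compound 2 also lies within the scatter. The steps of a number 13 percentage points higher from compound 1 to compound 2 (beyond the scatter) and a number 5 percentage points higher from compound 1 to compound 3 (within the scatter) show that an aryl group in place of cyclohexyl changes the maximal response only modestly, and the step of a number 8 percentage points lower from compound 2 to compound 3 (within the scatter) shows that exchanging one fluorophenyl for the other changes little.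

Compound 4 `Cc1cc(F)ccc1NC(=O)CN1CCC(c2cccc[n+]2[O-])CC1` differs from compound 3 in one place: 4-fluoro-2-methylphenyl in place of 2-fluorophenyl on an amide-type nitrogen. The entering group shares the 4-fluoro feature of the 4-fluorophenyl of compound 2. Among the measured compounds shown here, the steps that bear on this change are a number 8 percentage points lower from compound 2 to compound 3 (within the scatter) and a number 13 percentage points higher from compound 1 to compound 2 (beyond the scatter); both are small, so the step in this assay is expected to stay within the scatter, leaning upward if anywhere. Compound 4 is therefore expected to give 66%, within a range from 52% to 80%. The step this estimate implies is expected to be a number 3 percentage points higher from compound 3 to compound 4 (within the scatter).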

Compound 4, largest response reached (reported as efficacy), in percent of the reference or control that the assay uses: 84%
Estimate against measurement, compound 4: 18 percentage points below; measured number outside the range, above it.
By their numbers in this assay, from the lowest: compounds 1, 3 and 2 (each within the scatter of the next, the first and the last beyond it); then compound 4.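

In this assay, among the compounds shown here, methyl in place of hydrogen on an aromatic carbon is the only difference in the step of a number 13 percentage points higher from compound 2 to compound 4 (beyond the scatter) and so shows that this small addition to the 4-fluorophenyl group can move the maximal response beyond the scatter. The larger exchanges agree, with a number 21 percentage points higher from compound 3 to compound 4 (beyond the scatter) and a number 26 percentage points higher from compound 1 to compound 4 (beyond the scatter) both beyond the scatter, whereas the earlier swap of one fluorophenyl for the other, a number 8 percentage points lower from compound 2 to compound 3 (within the scatter) and so within the scatter, had suggested little sensitivity at this amide-type nitrogen; compound 4 now stands clear of all three earlier compounds, which means the aryl group here has more influence on the response than those compounds revealed. Nothing in the data given explains why the added methyl raises the response.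

As far as these compounds go, what a 2-methylphenyl group on the amide-type nitrogen would give, without any fluorine, stays open, so the share of the fluorine in the 4-fluoro-2-methylphenyl group in this result cannot be told. Also open, from the compounds shown here alone, is whether an ethyl group, a methoxy group or a chlorine atom in place of the methyl would keep the response as high.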